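Pyrrolidin-1-yl to piperidin-1-yl at the assay limit

This account rests on a few compounds, and the source may have more. Where it says the series, first, only, none or still open, it means among the compounds named here.

In a functional assay on SK-MEL-28 cells (Homo sapiens) for cytotoxicity, read by MTT assay, with a stated time of 72 h (a higher number here means a weaker inhibitor, a lower number a stronger inhibitor), compound 1 (`N#Cc1sc(N2CCCC2)nc1Cl`) gives > 100000 nM, which is a limit and not a number. Compound 2 (`COC(=O)c1sc2nc(SC)sc2c1C`) gives > 100000 nM, again a limit. Compound 3 (`COC(=O)c1sc2nc(N3CCCC3)sc2c1C`) gives > 100000 nM, also a limit. All three compounds share (the limit of > 100000 nM in this assay, at which 3 of the 3 values shown sit), so no order among them can be read.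

Compound 4 (`COC(=O)c1sc2nc(N3CCCCC3)sc2c1C`) carries piperidin-1-yl in place of pyrrolidin-1-yl on an aromatic carbon. For the measured compounds named here, the one measured step at this place is a step that the two limits leave unreadable from compound 2 to compound 3 and gives no size to carry over. No change beyond the scatter is expected in this assay, in either direction, and the expected step is a number no higher from compound 3 to compound 4 (the limit leaves the size open) as an estimate only. For compound 4 the expected value is 100000 nM, with an estimated range from 50000 nM to 200000 nM, and a report as a limit is the likeliest outcome.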

Compound 4, half-maximal inhibitory concentration: > 100000 nM
Compound 4: no number, only a limit; the forecaster's own chance of this, stated with the estimate: 90%; the middle value lies on the limit itself.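

Steps from compound 2 and compound 3 to compound 4 cannot be read in this assay, as all values are limits: the limit of > 100000 nM in this assay, at which 4 of the 4 values shown sit.

The compounds shown leave open whether any group at this place on the shared core gives a readable value.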